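The source may hold more compounds than are shown below. What is called first, only, known or untested is meant among the compounds shown, and "the series" means these compounds.

Compound 1 `CC(C)(C)C1=CC(=O)C=C(NCc2ccccc2)C1=O` is the reference point of this small set. In a functional assay on NCI-H460 cells (Homo sapiens) for cytotoxicity, read by MTT assay, with a stated time of 72 h (on this read-out higher numbers stand for weaker inhibition and lower numbers for stronger inhibition), compound 1 gives 14000 nM. Compound 2 `CNC1=CC(=O)C=C(C(C)(C)C)C1=O` differs from it in one place, (hydrogen in place of phenyl on a saturated chain carbon bound to an amine nitrogen), and in this assay compound 2 gives 25000 nM; the step of a 1.8-fold higher number from compound 1 to compound 2 (0.25 log units; within the scatter) is described as lying within the usual scatter of such measurements.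

Compound 3 `CC(C)(C)C1=CC(=O)C(NCc2ccccc2)=CC1=O` carries the same atoms as compound 1 joined differently; the difference between the two cores is not broken down here. In this assay compound 3 gives 19000 nM, a figure that sits within the scatter of both compound 1 and compound 2.

Compound 4 `CNC1=CC(=O)C(C(C)(C)C)=CC1=O` has not yet been measured. It stands to compound 3 as compound 2 stands to compound 1, with the same change, (hydrogen in place of phenyl on a saturated chain carbon bound to an amine nitrogen), at the same place. Because the earlier step of a 1.8-fold higher number from compound 1 to compound 2 (0.25 log units; within the scatter) stayed within the scatter, the expected step of a 1.8-fold higher number from compound 3 to compound 4 (0.25 log units; within the scatter) is taken to be of like size. On that basis compound 4 is estimated to give 34000 nM in this assay, most likely between 15000 nM and 70000 nM.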

Compound 4, half-maximal inhibitory concentration: 63000 nM
Compound 4: middle estimate off by 1.9-fold (0.27 log units), on the low side; low and high end bracket the measured number.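

In this assay, putting hydrogen in place of phenyl on the saturated chain carbon bound to the amine nitrogen gives a 3.3-fold higher number from compound 3 to compound 4 (0.52 log units; beyond the scatter). Set beside the same change on the core of compound 1, this step points the same way, and the gap between the two steps does not exceed the scatter: the same change on two cores in this assay, a 1.8-fold higher number (0.25 log units; within the scatter) from compound 1 to compound 2 and a 3.3-fold higher number (0.52 log units; beyond the scatter) from compound 3 to compound 4, 1.9-fold (0.27 log units) apart, within the scatter of two such steps. The change therefore carries over between these two cores in direction and, as far as can be told, in size, but this does not show that the core of compound 3 responds more strongly, and two pairs in one cell assay do not make a rule for the series.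

The compounds shown have only phenyl or hydrogen at this place, so it stays open how a chlorophenyl, a pyridyl ring or a longer alkyl chain would behave there. Going by these compounds, it also stays open whether the same step would hold on a core with a methyl group in place of the tert-butyl group.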